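The compounds below may be only part of what the source reports. "The series", "measured", "known", "first", "only" and "open" are said of these compounds alone.

Working notes on the series. Among the measured compounds shown here, compound 1 `Cc1cc(F)cnc1N1CCN(C(=O)CCS(=O)(=O)c2cccc3ncsc23)[C@@H](C)C1` is the only member with a number: in an ADME assay on microsomes from liver (Rattus norvegicus) for metabolic stability, read by LC-MS, with a stated time of 15 min, tested at 1 uM (on this read-out higher numbers stand for a more stable compound and lower numbers for a less stable compound), compound 1 gives 9.6%, the low end of the scale. Compound 2 `Cc1ccncc1N1CCN(C(=O)CCS(=O)(=O)c2cccc3ncsc23)CC1` shares the core of compound 1 and carries 4-methylpyridin-3-yl on an amine nitrogen in a ring, but in this assay compound 2 gives "not determined" (no result reported), so there is no single number for it to stand on. Compound 3 `O=C(CCS(=O)(=O)c1cccc2ncsc12)N1CCN(c2ccncc2F)CC1` differs from compound 2 by 3-fluoropyridin-4-yl in place of 4-methylpyridin-3-yl on an amine nitrogen in a ring. For the measured compounds named here, no measured step involves this pair, and with compound 2 unmeasured the size and direction of the step from compound 2 to compound 3 in this assay cannot be read from the data; no shift beyond the usual scatter is assumed either way. The expectation for compound 3 rests on compound 1, whose 9.6% in this assay is the only anchor, and compound 3 is estimated at 15%, with a range from 3% to 45%.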

Compound 3, percent of the compound remaining: 29%
Beside the measured number, compound 3's estimate is 14 percentage points below it; the measured number falls inside the stated range.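

Among the compounds shown here, compound 3 yields no new step, since compound 2 has no single number in this assay to set against it. Nothing available bears on the cause of this result. The compounds shown leave open how 3-fluoropyridin-4-yl and 4-methylpyridin-3-yl compare on the shared core.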